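The source may hold more compounds than are shown below. What is called first, only, known or untested is meant among the compounds shown, and "the series" means these compounds.

Compounds measured in an ADME assay on a cell-free system (plasma, Mus musculus) for metabolic stability, tested at 1 uM; on this read-out higher numbers stand for a longer-lived compound and lower numbers for a shorter-lived compound:
Compound 1 `C=CC(=O)N1CCN(S(=O)(=O)c2ccc(NC(=O)OCc3ccccc3)cc2)CC1`: > 6 h
Compound 2 `C=CC(=O)N[C@@H]1CCN(S(=O)(=O)c2ccc(NC(=O)OCc3ccccc3)cc2)C1`: > 6 h
Compound 3 `C=CC(=O)NC1CCN(S(=O)(=O)c2ccc(C(=O)NCc3ccccc3)cc2)CC1`: > 6 h

Compound 3 gives > 6 h, which is a limit of the assay and not a number. On these data alone, its true half-life therefore remains unknown, and the same is true of the other two compounds. The whole record so far is the limit of > 6 h in this assay, at which 3 of the 3 values shown sit.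

Compound 4 `C=CC(=O)NC1CCN(S(=O)(=O)c2ccc(C(=O)N(C)Cc3ccccc3)cc2)CC1` comes from compound 3 through one small change, (methyl in place of hydrogen on an amide-type nitrogen). In words, this is methyl in place of hydrogen on an amide-type nitrogen, or benzylamino to benzyl(methyl)amino.

Only one measured step links two of these compounds: a step that the two limits leave unreadable from compound 1 to compound 2. It concerns a different part of the molecule and has no readable size, so it offers no number to carry over. Going by the values given here, no measured step tests the new methyl. With nothing pointing either way, no step beyond the usual scatter is expected in this assay, and no direction can be predicted. Another limit is the most likely report.

The expected change is a step that the limit leaves unreadable from compound 3 to compound 4. For compound 4, the estimated half-life is 8 h, with an expected range from 4 h to 24 h.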

Compound 4, half-life: > 6 h
Compound 4 ended at the assay's limit; the forecaster's own chance of this, stated with the estimate: 85%; the middle value is on the limit's open side.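

In this assay compound 4 gives > 6 h, which is a limit of the assay and not a number. Going by these compounds alone, compound 3 also stands at a limit, so no step from it to compound 4 can be read. The compounds shown leave open how long each one truly lasts and whether any of these structural changes alters that, as all the results sit at one value: the limit of > 6 h in this assay, at which 4 of the 4 values shown sit.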